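Amide nitrogen substituent: benzyl against heteroaryl

A few compounds are considered here, and "the series" means these few. Any claim that something is new, unique, unknown or untested is made for them only; others in the source may bear on it.

Compound 1 `CC(C)C(C(N)=O)c1ccc(Cl)cc1` is the primary amide of the shared core. In a functional assay on CHO cells for agonist activity at Free fatty acid receptor 2 (Homo sapiens), read by cAMP accumulation (on this read-out higher numbers stand for weaker inhibition and lower numbers for stronger inhibition), compound 1 reaches only the assay limit, > 100000 nM. Compound 2 `CC(C)[C@H](C(=O)NCc1ccccc1)c1ccc(Cl)cc1` is the benzyl amide. In this assay compound 2 likewise gives only a limit, > 100000 nM. Compound 2 therefore stands among the values that are limits and not numbers (the limit of > 100000 nM in this assay, at which 2 of the 3 values shown sit). Compound 3 `CC(C)[C@H](C(=O)Nc1ccccn1)c1ccc(Cl)cc1` puts pyridin-2-yl directly on the amide nitrogen, and in this assay compound 3 gives 1400 nM. Among the measured compounds shown here, the one step that differs in a single place is an at least 71-fold lower number from compound 2 to compound 3 (1.85 log units; beyond the scatter).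

Compound 4 `Cc1csc(NC(=O)[C@H](c2ccc(Cl)cc2)C(C)C)n1` is not yet measured. Its change from compound 2 is 4-methyl-1,3-thiazol-2-yl in place of benzyl on an amide-type nitrogen. This parallels the change from compound 2 to compound 3: again a heteroaromatic ring replaces benzyl on the amide nitrogen, though now one five-membered aromatic ring with 2 hetero atoms. Because an at least 71-fold lower number from compound 2 to compound 3 (1.85 log units; beyond the scatter) is large, a drop of similar size is expected for compound 4. In this assay compound 4 is expected to give about 1500 nM, between 300 nM and 10000 nM. That corresponds to an expected step of an at least 66-fold lower number from compound 2 to compound 4 (1.82 log units; beyond the scatter). As compound 2 is only a limit, this estimated step is itself a lower bound.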

Compound 4, half-maximal inhibitory concentration: 1400 nM
Compound 4: the middle estimate sits 1.1-fold (0.03 log units) above what was measured; the range from low to high includes it.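

In this assay, the large drop on leaving benzyl is not peculiar to pyridin-2-yl: 4-methyl-1,3-thiazol-2-yl on the amide-type nitrogen gives an at least 71-fold lower number from compound 2 to compound 4 (1.85 log units; beyond the scatter). The two heteroaromatic groups are not separated by this read-out, with no change at the digits printed from compound 3 to compound 4 (within the scatter), so one five-membered aromatic ring with 2 hetero atoms is tolerated here on a par with pyridin-2-yl. The true size of the step away from benzyl stays unknown because compound 2 is a limit and not a number: the limit of > 100000 nM in this assay, at which 2 of the 4 values shown sit.

The compounds shown do not separate the effect of the hetero atoms from that of a ring set directly on the amide nitrogen; a plain phenyl group at this nitrogen would be the comparison that does. They also leave open how far this position accepts further substitution, for example a carboxylic acid on the heteroaromatic ring or a longer chain in place of the methyl of 4-methyl-1,3-thiazol-2-yl.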